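The source may report more compounds than this note shows. Statements on the series, on what has been measured and on what is new or still open speak of the compounds shown alone.

Measured compounds:
compound 1, `Cc1cccc(CN(C)C(=O)c2cc(Cl)c(O)cc2O)c1`, 49300 nM in a functional assay on NCI-H1975 cells (Homo sapiens) for antiproliferative activity, with a stated time of 72 h; on this read-out lower numbers stand for stronger inhibition of growth and higher numbers for weaker inhibition of growth
compound 2, `Cc1ccccc1CN(C)C(=O)c1cc(Cl)c(O)cc1O`, 47500 nM

Compound 1 and compound 2 share one core and differ only in the position of the methyl on the phenyl. Going by the values given here, the one step known, a 1.0-fold lower number from compound 1 to compound 2 (0.02 log units; within the scatter), is within the scatter, so the two numbers are taken as equal. Compound 2 thus holds the lower of two numbers in this assay, with compound 1 at the same level.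

Compound 3, `CN(Cc1ccccc1)C(=O)c1cc(Cl)c(O)cc1O`, is not yet measured. It differs from compound 2 by hydrogen in place of methyl on an aromatic carbon. Among the compounds with values here, no measured step removes a methyl; the one step known, a move of the methyl, changed nothing beyond scatter. On that basis the expected step is a 1.1-fold higher number from compound 2 to compound 3 (0.02 log units; within the scatter), with no direction beyond the scatter. For compound 3 the estimate in this assay is 50000 nM, with a range from 22000 nM to 110000 nM.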

Compound 3, concentration for 50% growth inhibition: 35500 nM
Compound 3: the middle estimate sits 1.4-fold (0.15 log units) above what was measured, within the range that was stated.
By their numbers in this assay, from the lowest: compounds 3, 2 and 1 (each within the scatter of the next).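

In this assay, hydrogen in place of methyl on the aromatic carbon gives a 1.3-fold lower number from compound 2 to compound 3 (0.13 log units; within the scatter), and the same exchange read from the other methyl position gives a 1.4-fold lower number from compound 1 to compound 3 (0.14 log units; within the scatter). The earlier pair showed only that moving the methyl left the number level; these steps add that the plain phenyl sits at the same level, so neither methyl position is needed to hold the growth inhibition seen here. Nothing at hand bears on why this position responds so little.

On these data alone, only methyl and hydrogen appear on this phenyl, so it remains open whether a methoxy group, a chlorine, an amine or a carboxylic acid there would move the number beyond the scatter. As far as these compounds go, the chlorine and the two hydroxyl groups of the shared core stay constant throughout, so their part also remains open.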